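The source may hold more compounds than are shown below. What is called first, only, known or untested is meant among the compounds shown, and "the series" means these compounds.

Compound 1 `CS(=O)(=O)N1CCC(CN(Cc2ccc(Cl)cc2)Cc2ccc([N+](=O)[O-])s2)C1` carries a methyl group on its sulfonyl sulfur, and in a functional assay on HEK293 cells for agonist activity at nuclear receptor subfamily 1 group D member 1 (Homo sapiens), read by a luciferase reporter, with a stated time of 24 h (on this read-out higher numbers stand for an effect only at larger amounts of compound and lower numbers for an effect already at smaller amounts), compound 1 gives 570 nM. Compound 2 `Cc1ccc(S(=O)(=O)N2CCC(CN(Cc3ccc(Cl)cc3)Cc3ccc([N+](=O)[O-])s3)C2)cc1` differs only in the group on that sulfur, and in this assay compound 2 stands as "not determined" (no result reported), so it contributes no number to the comparison. Compound 3 `O=[N+]([O-])c1ccc(CN(Cc2ccc(Cl)cc2)CC2CCN(S(=O)(=O)Cc3ccccc3)C2)s1` is the benzylsulfonyl analogue, and in this assay compound 3 gives 630 nM. Among the two numbers available, compound 3 sits alongside compound 1 within the scatter, and the step of a 1.1-fold higher number from compound 1 to compound 3 (0.04 log units; within the scatter) shows that adding a phenyl at the sulfonyl substituent left the read-out essentially unchanged. Compound 4 `O=[N+]([O-])c1ccc(CN(Cc2ccc(Cl)cc2)CC2CCN(S(=O)(=O)c3cccc4ccccc34)C2)s1` is the next member of this series; it differs from compound 3 by naphthalen-1-yl in place of benzyl on a sulfonyl sulfur. This again alters only the group on the sulfonyl sulfur. Going by the values given here, the one measured step at this position is the only guide, and because a 1.1-fold higher number from compound 1 to compound 3 (0.04 log units; within the scatter) lay within the scatter, no step beyond the scatter is expected here either. Compound 4 is therefore estimated to give 650 nM, with a range from 250 nM to 1700 nM. The expected step is a 1.0-fold higher number from compound 3 to compound 4 (0.01 log units; within the scatter), a change within the scatter.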

Compound 4, half-maximal effective concentration: 450 nM
Compound 4: middle estimate off by 1.4-fold (0.16 log units), on the high side, and the stated range covers the measured number.
By their numbers in this assay, from the lowest: compounds 4, 1 and 3 (each within the scatter of the next).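

Placing naphthalen-1-yl on the sulfonyl sulfur, with 10 heavy atoms against the 7 of benzyl, still gives no step beyond the scatter: the comparison shows a 1.4-fold lower number from compound 3 to compound 4 (0.15 log units; within the scatter), and the comparison with the methyl group shows a 1.3-fold lower number from compound 1 to compound 4 (0.10 log units; within the scatter). With these steps, methyl, benzyl and naphthalen-1-yl all stand within the scatter of one another in this assay, so this position now accommodates a group with two six-membered aromatic rings of carbon only without a step that can be read as a real difference. No supporting data bear on why the read-out holds so steady here.

The compounds shown leave open whether a carboxylic acid, an amine or a longer chain on this sulfur would move the number beyond the scatter. They also leave open whether any group at this position can do so.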